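Notes on the arylamino change in the shared core

A few compounds are considered here, and "the series" means these few. Any claim that something is new, unique, unknown or untested is made for them only; others in the source may bear on it.

Compound 2 `COc1cc(C(=O)c2sc3ccccc3c2-c2ccc(SC)cc2)cc(OC)c1OC` gives 1800 nM in a functional assay on K562 cells (Homo sapiens) for antiproliferative activity, read by MTT assay, with a stated time of 72 h (on this read-out lower numbers stand for stronger inhibition and higher numbers for weaker inhibition), standing second highest of the three numbers recorded so far; its nearest neighbour is compound 3 `COc1cc(C(=O)c2sc3ccccc3c2Nc2ccc(Cl)cc2)cc(OC)c1OC` with 1100 nM, and compound 1 `COc1cc(C(=O)c2sc3ccccc3c2-c2ccc(Cl)cc2)cc(OC)c1OC` with 4200 nM lies furthest from it. Compound 4 `CCOc1ccc(Nc2c(C(=O)c3cc(OC)c(OC)c(OC)c3)sc3ccccc23)cc1` carries (4-ethoxyphenyl)amino in place of 4-(methylsulfanyl)phenyl on an aromatic carbon. Among the compounds with values here, two measured steps bear on this change: a 1.6-fold lower number from compound 2 to compound 3 (0.21 log units; within the scatter) and a 3.8-fold lower number from compound 1 to compound 3 (0.58 log units; beyond the scatter), both moving the same way when an arylamino group replaces an aryl group. Within the data shown here, no measured pair separates the ethoxy group from the chloro or methylsulfanyl group. The expectation for compound 4 in this assay is therefore a modest lowering, a 2.0-fold lower number from compound 2 to compound 4 (0.30 log units; within the scatter). Compound 4 is estimated at 900 nM, with a range from 400 nM to 2500 nM.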

Compound 4, half-maximal inhibitory concentration: 200 nM
Compound 4: the middle estimate sits 4.5-fold (0.65 log units) above what was measured, and the stated range ends above it.
By their numbers in this assay, from the lowest: compound 4; then compounds 3 and 2 (each within the scatter of the next); then compound 1.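

In this assay the amino link held constant, ethoxy in place of chloro gives a 5.5-fold lower number from compound 3 to compound 4 (0.74 log units; beyond the scatter) and so shows that the group on the aryl ring of this substituent moves the number beyond the scatter. The full change to (4-ethoxyphenyl)amino gives a 9.0-fold lower number from compound 2 to compound 4 (0.95 log units; beyond the scatter) and a 21-fold lower number from compound 1 to compound 4 (1.32 log units; beyond the scatter) and leaves compound 4 lowest of the four. No measurement shown accounts for this drop.

Open, as far as these compounds go, is whether a methoxy group, a longer butoxy chain or a dimethylamino group in place of ethoxy would hold this gain, and whether ethoxy gives a like step without the amino link.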